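The source may hold more compounds than are shown below. What is called first, only, known or untested is meant among the compounds shown, and "the series" means these compounds.

Measured compounds:
Compound 1 `C/C(=N\NC(=O)c1cccc(S(=O)(=O)N2CCOCC2)c1)c1cc(F)ccc1O` gives 3270 nM in a functional assay on ECa-109 cells for antiproliferative activity against ECa-109 cell line (Homo sapiens), read by MTT assay, with a stated time of 72 h; on this read-out lower numbers stand for stronger inhibition and higher numbers for weaker inhibition.
Compound 2 `O=C(N/N=C/c1ccco1)c1cccc(S(=O)(=O)N2CCOCC2)c1` gives > 100000 nM in this assay, and this is a limit of the assay, not a number.

Of the two measured compounds, compound 2 therefore stands only at a limit, and it sits at the limit of > 100000 nM in this assay, at which 1 of the 2 values shown sits. Among the measured compounds shown here, compound 1 is the one compound with a measured number. For the measured compounds named here, no two measured compounds differ in a single place, so there is no measured step to lean on.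

Compound 3 `COc1ccc(/C=N/NC(=O)c2cccc(S(=O)(=O)N3CCOCC3)c2)c(O)c1` differs from compound 2 by 2-hydroxy-4-methoxyphenyl in place of furan-2-yl on a carbon with a double bond to nitrogen, in words 2-hydroxy-4-methoxyphenyl in place of furan-2-yl on a carbon with a double bond to nitrogen. Going by the values given here, with no measured step of this kind, the expectation rests on the spread of the two values. Compound 1 gives a number at 3270 nM. Compound 2 reaches only a limit of the assay. Compound 3 is therefore expected to land between the two, closer to the number of compound 1 than to the limit of compound 2. The step from compound 2 to compound 3 is estimated as an at least 8.3-fold lower number from compound 2 to compound 3 (0.92 log units; beyond the scatter), a downward move beyond the scatter. Compound 3 is estimated at 12000 nM, with a range from 2500 nM to 60000 nM.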

Compound 3, half-maximal inhibitory concentration: 2790 nM
Estimate against measurement, compound 3: 4.3-fold (0.63 log units) above; the measured number falls inside the stated range.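

In this assay, the carbon with a double bond to nitrogen now has a measured step: putting 2-hydroxy-4-methoxyphenyl in place of furan-2-yl gives an at least 35-fold lower number from compound 2 to compound 3 (1.55 log units; beyond the scatter), a large move that shows this one change can carry a compound from no number at all to a measured number. Compound 2 gives > 100000 nM, which is a limit of the assay and not a number. The step can therefore be read only as a bound and not as an exact size, because of where compound 2 stands: the limit of > 100000 nM in this assay, at which 1 of the 3 values shown sits.

The change replaces a five-membered ring with a six-membered one and brings in a hydroxy and a methoxy group all at once, so the compounds shown cannot tell which of these parts carries the step. As far as these compounds go, it remains open how this read-out would respond to a plain phenyl group on the same carbon, which would help separate the effect of the ring from that of its two added groups.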